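Phenyl in Place of Hydrogen on a Shared Core

The source may hold more compounds than are shown below. What is called first, only, known or untested is meant among the compounds shown, and "the series" means these compounds.

Compound 1 `O=C(CCCCC1CCSS1)NCc1cn(CCCOc2ccc3ccc(=O)oc3c2)nn1`: 40%
Compound 2 `O=C(CCCCC1CCSS1)NCc1cn(CCCOc2ccc3cc(-c4ccc(Br)cc4)c(=O)oc3c2)nn1`: 63.3%
Compound 3 `O=C(CCCCC1CCSS1)NCc1cn(CCCCOc2ccc3ccc(=O)oc3c2)nn1`: 65.1%

In a functional assay on PC-12 cells (Rattus norvegicus) for cytotoxicity, read by MTT assay, with stated times of 3 h and 2 h, tested at 10 uM (a higher number here means a stronger effect of the compound at the concentration tested, a lower number a weaker effect), compound 3 gives 65.1%, the highest of the three numbers measured. Compound 2 lies within the scatter of it, so no order between the two can be claimed, while compound 1 lies beyond the scatter below it.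

Compound 4 `O=C(CCCCC1CCSS1)NCc1cn(CCCCOc2ccc3cc(-c4ccccc4)c(=O)oc3c2)nn1` has not been measured in this assay. It differs from compound 3 in one place: phenyl in place of hydrogen on an aromatic carbon.

Among the compounds with values here, only one measured step bears on this change. From compound 1 to compound 2 a 4-bromophenyl replaced hydrogen at the same position, and the read-out in this assay rose by a number 23.3 percentage points higher from compound 1 to compound 2 (beyond the scatter), a modest rise beyond the scatter. The change from compound 3 to compound 4 places a plain phenyl at that position, with compound 3 already starting from a higher number than compound 1. A rise in the same direction is therefore expected, though with less room above the starting point and with the uncertainty that the measured precedent carried a bromine that compound 4 lacks.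

For compound 4 the expected step in this assay is a number 12.9 percentage points higher from compound 3 to compound 4 (beyond the scatter), and its estimated value is 78%, within a range of 62% to 92%.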

Compound 4, a percentage reported as activity, at one concentration (the size of the read-out at that concentration, not a potency): 30.5%
Estimate against measurement, compound 4: 47.5 percentage points above; measured number below the stated range.
By their numbers in this assay, from the lowest: compounds 4 and 1 (each within the scatter of the next); then compounds 2 and 3 (each within the scatter of the next).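

At this position a plain phenyl does not behave like the earlier 4-bromophenyl: in this assay the read-out moves a number 34.6 percentage points lower from compound 3 to compound 4 (beyond the scatter), a large step, whereas the earlier replacement gave a number 23.3 percentage points higher from compound 1 to compound 2 (beyond the scatter). Adding an aromatic ring at this carbon therefore has no single direction of effect across the compounds shown, and the result of one such replacement cannot simply be carried over to another parent compound. The data offer no measurement that explains this reversal.

As far as these compounds go, the two steps differ in two ways at once, the bromine on the added ring and the length of the chain on the shared core, so it remains open which of these goes with the change of direction; a 4-bromophenyl on the core of compound 3, or a plain phenyl on the core of compound 1, would separate them. Also open, from the compounds shown here alone, is how the read-out would respond at this carbon to other groups, such as a 4-methoxyphenyl, a 4-chlorophenyl or a simple amine.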